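Cyclopropyl for butyl on the shared core: what to expect

The compounds below may be only part of what the source reports. "The series", "measured", "known", "first", "only" and "open" are said of these compounds alone.

Compound 1 `CCCCNc1nc(-c2ccccc2)nc2c1nnn2Cc1ccccc1C(F)(F)F` gives 6500000 nM in an assay on isolated protein for binding affinity to adenosine receptor A1 (Bos taurus); a higher number here means a weaker inhibitor, a lower number a stronger inhibitor. Compound 2 `CCCCNc1nc(-c2ccccc2)nc2c1nnn2Cc1ccccc1F` gives 4300000 nM. Compound 3 `CCCCNc1nc(-c2ccccc2)nc2c1nnn2Cc1ccccc1` gives 11000000 nM.

Among these three, compound 1 stands second highest. Its nearest neighbour is compound 2, with a 1.5-fold lower number from compound 1 to compound 2 (0.18 log units; within the scatter); the furthest is compound 3, with a 1.7-fold higher number from compound 1 to compound 3 (0.23 log units; within the scatter). Between those two, a 2.6-fold higher number from compound 2 to compound 3 (0.41 log units; beyond the scatter) is the only step that reaches beyond the scatter, and all three steps concern the substituent on the benzyl ring, not the amine.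

Compound 4 `FC(F)(F)c1ccccc1Cn1nnc2c(NC3CC3)nc(-c3ccccc3)nc21` differs from compound 1 in another place: cyclopropyl in place of butyl on a nitrogen on an aromatic ring. Within the data shown here, none of the measured steps touches this amino substituent, so nothing here tells how this assay answers to it. With the three values lying within a narrow band, the expectation for compound 4 is a number close to that of compound 1, with no step beyond the scatter in either direction; the expected step is no change at the digits printed from compound 1 to compound 4 (within the scatter). Compound 4 is therefore estimated at 6500000 nM, with a range from 2000000 nM to 20000000 nM.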

Compound 4, inhibition constant: 7800000 nM
The estimate for compound 4 lay 1.2-fold (0.08 log units) below the measured number; measured number inside the range.
By their numbers in this assay, from the lowest: compounds 2, 1, 4 and 3 (each within the scatter of the next, the first and the last beyond it).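

In this assay, the step from butylamino to cyclopropylamino gives a 1.2-fold higher number from compound 1 to compound 4 (0.08 log units; within the scatter). Among these compounds, this is the first reading at this position, as all the earlier steps changed a different place on the shared core. With the trifluoromethyl group held constant, the assay does not separate the open butyl chain from the three-membered ring with its smaller carbon count, and nothing available here bears on why the two read alike.

This one pair leaves open whether cyclopropyl and butyl would also read alike alongside the fluoro group of compound 2 or the unsubstituted ring of compound 3. It also leaves open how this position would answer to an unsubstituted amino group, a cyclopentyl ring or a longer chain such as hexyl.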